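Shortening the Unsaturated Chain of Compound 2

The source may hold more compounds than are shown below. What is called first, only, known or untested is meant among the compounds shown, and "the series" means these compounds.

The shared core carries a trimethoxyphenyl group on an amide-type nitrogen, which also bears a benzyl-type arm and an unsaturated acyl chain. Compound 1 `C/C=C/C(=O)N(Cc1cccc(O)c1)c1cc(OC)c(OC)c(OC)c1` gives 14700 nM in a functional assay on KYSE-450 cells (Homo sapiens) for inhibition, read by MTT assay, with a stated time of 48 h; on this read-out lower numbers stand for stronger inhibition and higher numbers for weaker inhibition. Compound 3 `C/C=C/C(=O)N(Cc1ccc(OC)c(Cl)c1)c1cc(OC)c(OC)c(OC)c1` gives 10100 nM; the step of a 1.5-fold lower number from compound 1 to compound 3 (0.16 log units; within the scatter) stays within the scatter. Compound 2 `CCC/C=C/C(=O)N(Cc1ccc(OC)c(O)c1)c1cc(OC)c(OC)c(OC)c1` gives 57 nM, the lowest of the three numbers, with gaps to both compound 1 and compound 3 that lie beyond the scatter, so compound 2 is the most potent compound measured.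

Compound 4 `CC/C=C/C(=O)N(Cc1ccc(OC)c(O)c1)c1cc(OC)c(OC)c(OC)c1` differs from compound 2 by hydrogen in place of methyl on a saturated chain carbon, two bonds along the chain from a double-bonded chain carbon, that is, pent-1-en-1-yl becomes but-1-en-1-yl. Among the compounds with values here, no measured step touches this chain: compound 1 and compound 3 differ from compound 2 in both the chain and the benzyl-type arm at once, so their values cannot be read as a chain effect alone. Within the data shown here, the only step measured changes the arm and stays within the scatter. With no direct guide, a small step, if any, is expected for compound 4, as a modest rise from a 2.6-fold higher number from compound 2 to compound 4 (0.42 log units; beyond the scatter). Compound 4 is therefore estimated at 150 nM, between 40 nM and 600 nM.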

Compound 4, half-maximal inhibitory concentration: 72 nM
Estimate against measurement, compound 4: 2.1-fold (0.32 log units) above; the measured number falls inside the stated range.
By their numbers in this assay, from the lowest: compounds 2 and 4 (each within the scatter of the next); then compounds 3 and 1 (each within the scatter of the next).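

In this assay, going from pent-1-en-1-yl to but-1-en-1-yl gives a 1.3-fold higher number from compound 2 to compound 4 (0.10 log units; within the scatter), so removing this methyl from the end of the chain produces no readable difference. Within the data shown here, this is the first step that changes the unsaturated chain while leaving the benzyl-type arm and the rest of the molecule untouched, and it shows that this position accepts hydrogen in place of methyl without leaving the range of ordinary repeat measurements. No evidence is available to explain why this change is tolerated.

From the compounds shown here alone, the result covers only this single trimming of the chain, so it remains open whether a longer chain such as hex-1-en-1-yl, or a chain ending in an amine or a carboxylic acid, would also be accepted. Also open, going by these compounds, is how much of the wide gap between compound 2 and both compound 1 and compound 3 belongs to the chain and how much to the arm, as each of those two compounds differs from compound 2 in both places at once.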